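Removing a tert-Butoxycarbonyl Group on Two Cores

The source may hold more compounds than are shown below. What is called first, only, known or untested is meant among the compounds shown, and "the series" means these compounds.

Compound 1 `CC(C)(C)OC(=O)N[C@@H](C(=O)NNC(=O)c1ccc([N+](=O)[O-])o1)c1ccccc1` and compound 2 `N[C@@H](C(=O)NNC(=O)c1ccc([N+](=O)[O-])o1)c1ccccc1` differ in one place: hydrogen in place of tert-butoxycarbonyl on an amine nitrogen. In a functional assay (Mus musculus) for cytotoxicity (a lower number here means that less compound is tolerated, a higher number that more compound is tolerated), compound 1 gives 32000 nM, and compound 2 gives 32000 nM, so that no change at the digits printed from compound 1 to compound 2 (within the scatter). Compound 3 `CC(C)(C)OC(=O)Nc1ccc2cc(C(=O)NNC(=O)c3ccc([N+](=O)[O-])o3)ccc2c1` carries the same tert-butoxycarbonyl group on another core; the difference between the two cores is not broken down here. In this assay compound 3 gives 32000 nM, level with compounds 1 and 2 within the scatter. Compound 4 `Nc1ccc2cc(C(=O)NNC(=O)c3ccc([N+](=O)[O-])o3)ccc2c1` is not yet measured; it differs from compound 3 in that (hydrogen in place of tert-butoxycarbonyl on a nitrogen on an aromatic ring). This is the same kind of change as from compound 1 to compound 2, but here the nitrogen sits on an aromatic ring with an aromatic carbon as its other neighbour, rather than on an amine nitrogen whose other neighbour is a saturated chain carbon. Because no change at the digits printed from compound 1 to compound 2 (within the scatter), compound 4 is expected to show a step of about no change at the digits printed from compound 3 to compound 4 (within the scatter). Compound 4 is estimated at 32000 nM, most likely between 16000 nM and 64000 nM.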

Compound 4, half-maximal cytotoxic concentration: 32000 nM
Compound 4: the middle estimate sits on the measured number at the digits printed; the range from low to high includes it.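

In this assay, taking the tert-butoxycarbonyl group off the nitrogen on an aromatic ring gives no change at the digits printed from compound 3 to compound 4 (within the scatter). Set beside the same change on the other core, the step carries over between the two cores in this assay: the same change on two cores in this assay, no change at the digits printed (within the scatter) from compound 1 to compound 2 and no change at the digits printed (within the scatter) from compound 3 to compound 4, 1.0-fold (0.00 log units) apart, within the scatter of two such steps. This shows agreement for one change on two cores in one assay, but it does not show that the change would behave alike on any further core or in any other assay.

The compounds shown leave open whether another group on this nitrogen, such as an acetyl group or a longer chain, would give a different value. From the compounds shown here alone, whether any change elsewhere in these molecules would move the value also remains open.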